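Chloro for Fluoro on the Urea Aryl Ring

A few compounds are considered here, and "the series" means these few. Any claim that something is new, unique, unknown or untested is made for them only; others in the source may bear on it.

Three compounds built on the shared core of compound 1 `O=C(Nc1cccc(F)c1)Nc1cc2ncncc2cc1OCc1cccc(Cl)c1` have been measured in an ADME assay on cells (Astrocyte, Homo sapiens) for cytotoxicity, read by WST assay, with a stated time of 72 h; a higher number here means a weaker inhibitor, a lower number a stronger inhibitor. Compound 1 reaches only the limit of the measurement, giving > 10000 nM. Compound 2 `O=C(Nc1cc2ncncc2cc1OCc1cccc(F)c1)Nc1cccc2ccccc12` likewise sits at the limit, with > 10000 nM. Among the compounds with values here, compound 3 `O=C(Nc1cccc(F)c1)Nc1cc2ncncc2cc1OCc1ccccc1Cl` is the one compound with a number, giving 9400 nM. Within the data shown here, the single measured step between structures that differ in one place, an at least 1.0-fold lower number from compound 1 to compound 3 (0.02 log units; that floor lies within the scatter), lies within the scatter, and the fact that two of the three values sit at the limit of > 10000 nM in this assay, at which 2 of the 3 values shown sit, means the series is so far flat at the weak end of the scale.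

Compound 4 `O=C(Nc1cccc(Cl)c1)Nc1cc2ncncc2cc1OCc1cccc(Cl)c1` differs from compound 1 by chloro in place of fluoro on an aromatic carbon. Among the measured compounds shown here, no measured step touches this position: the only step measured, an at least 1.0-fold lower number from compound 1 to compound 3 (0.02 log units; that floor lies within the scatter), concerns a different ring and shows no change beyond the scatter. For the measured compounds named here, nothing among the measured compounds therefore points to a move in either direction. Compound 4 is expected to give about 12000 nM, within a range from 6000 nM to 30000 nM, most probably again reported only as a limit. The expected step that the limit leaves unreadable from compound 1 to compound 4 is nothing beyond the scatter.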

Compound 4, half-maximal inhibitory concentration: > 10000 nM
Compound 4: a limit, no number; the forecaster's own chance of this, stated with the estimate: 70%; the middle value is on the limit's open side.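

In this assay compound 4 gives > 10000 nM, which is a limit and not a number. Compound 1 gives > 10000 nM, also a limit, so no step can be read between these two compounds. The compounds shown leave open whether chloro in place of fluoro on this ring changes the true value at all.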